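The compounds below may be only part of what the source reports. "The series", "measured", "known", "first", "only" and "open" are said of these compounds alone.

Measured compounds:
compound 1, `CNC(=O)c1cc(Oc2ccc3nc(NC(=O)Nc4cc(C(F)(F)F)cc(C(F)(F)F)c4)sc3c2)ccn1`: 87.5%
compound 2, `CNC(=O)c1cc(Oc2ccc3nc(NC(=O)c4ccc(Cl)cc4Cl)sc3c2)ccn1`: 15.1%

In a functional assay on HCT-116 cells (Homo sapiens) for inhibition, read by MTT assay, with a stated time of 2 days, tested at 10 uM (a lower number here means less inhibition of growth, a higher number more inhibition of growth at the concentration tested), compound 1 gives 87.5% and compound 2 gives 15.1%. For the measured compounds named here, compound 2 therefore stands lowest of the two numbers; its only neighbour is compound 1, whose number lies higher by a margin beyond the usual scatter. The two compounds differ in more than one place, so their gap cannot be traced to a single change.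

Compound 3, `CNC(=O)c1cc(Oc2ccc3nc(NC(=O)c4ccc(Cl)cc4)sc3c2)ccn1`, is not yet measured. It differs from compound 2 by hydrogen in place of chloro on an aromatic carbon. Going by the values given here, no step of this kind between measured compounds is known, so the expectation rests on the low value of compound 2 alone. The step of a number 0.1 percentage points lower from compound 2 to compound 3 (within the scatter) is expected to be small and to stay within the scatter in either direction. Compound 3 is estimated at 15%, in a range from 3% to 35%.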

Compound 3, percent growth inhibition at one concentration: 27.5%
Compound 3: middle estimate off by 12.5 percentage points, on the low side; the range from low to high includes it.
By their numbers in this assay, from the lowest: compound 2; then compound 3; then compound 1.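

For the compounds shown here, replacing the chloro ortho to a large group with hydrogen, which turns the 2,4-dichlorophenyl into 4-chlorophenyl, gives the first step in this set that can be traced to a single change: in this assay it is a number 12.4 percentage points higher from compound 2 to compound 3 (beyond the scatter). This shows that the position bears on the read-out, and that the chloro there is not required for the growth inhibition seen, although the step is only modest. Nothing in the data gives a measured reason for the step.

The compounds shown leave open whether a methoxy group or an amine at this position would move the number further than hydrogen does. They also leave open what happens when the remaining chloro of the 4-chlorophenyl is replaced by hydrogen or by a methyl group.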